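The compounds below may be only part of what the source reports. "The series", "measured", "known", "first", "only" and "open" are said of these compounds alone.

In an assay on isolated protein for inhibition of DNA topoisomerase 1 (Homo sapiens), with a stated time of 30 min, tested at 100 uM (on this read-out higher numbers stand for a stronger effect at the one concentration tested and lower numbers for a weaker effect), three compounds have been measured. Compound 1 `Oc1ccccc1-c1cc(-c2cccs2)cc(-c2ccccc2O)n1` gives 77.2%, compound 2 `Oc1cccc(-c2cc(-c3cccs3)cc(-c3ccccc3O)n2)c1` gives 83.2%, and compound 3 `Oc1cccc(-c2cc(-c3ccoc3)cc(-c3ccccc3O)n2)c1` gives 29.5%. The change 3-hydroxyphenyl in place of 2-hydroxyphenyl on an aromatic carbon produced a step of a number 6 percentage points higher from compound 1 to compound 2 (within the scatter). Exchanging thiophen-2-yl for furan-3-yl produced a step of a number 53.7 percentage points lower from compound 2 to compound 3 (beyond the scatter). The difference between the cores of compound 1 and compound 3 is not broken down here. Compound 4 `Oc1cccc(-c2cc(-c3ccoc3)cc(-c3cccc(O)c3)n2)c1` has not yet been measured; it differs from compound 3 by 3-hydroxyphenyl in place of 2-hydroxyphenyl on an aromatic carbon, the same kind of change as before, though here the place is meta to a 3-hydroxyphenyl group and a furan-3-yl group rather than meta to a 2-hydroxyphenyl group and a thiophen-2-yl group. Because the earlier step of a number 6 percentage points higher from compound 1 to compound 2 (within the scatter) lay within the scatter, the expected step is a number 4.5 percentage points higher from compound 3 to compound 4 (within the scatter), a small one. Compound 4 is therefore estimated at 34%, with a likely range from 15% to 58%.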

Compound 4, a percentage reported as inhibition, at one concentration (the size of the read-out at that concentration, not a potency): 44.2%
The estimate for compound 4 lay 10.2 percentage points below the measured number, and the stated range covers the measured number.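

In this assay, 3-hydroxyphenyl in place of 2-hydroxyphenyl gave a step of a number 14.7 percentage points higher from compound 3 to compound 4 (beyond the scatter). Set beside the same change on the other core, the two steps do not differ measurably, so the change seems to carry over between these two cores: the same change on two cores in this assay, a number 6 percentage points higher (within the scatter) from compound 1 to compound 2 and a number 14.7 percentage points higher (beyond the scatter) from compound 3 to compound 4, 8.7 percentage points apart, within the scatter of two such steps. This rests on just two pairs, with only the newer step beyond the scatter, so it does not show that the change would behave alike on other cores, nor why it has this effect.

On these data alone, what an amine or a methoxy group would do in place of the hydroxyl remains open. So does the effect of a five-membered ring group other than thiophen-2-yl or furan-3-yl.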